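The source may hold more compounds than are shown below. What is called first, only, known or untested is meant among the compounds shown, and "the series" means these compounds.

Measured in a functional assay on MDA-MB-231 cells (Homo sapiens) for antiproliferative activity, read by MTT assay, with a stated time of 96 h; on this read-out lower numbers stand for stronger inhibition and higher numbers for weaker inhibition:
Compound 1 `CC(C)=CCC/C(C)=C/CC/C(C)=C/CC[C@]1(C)CCc2cc(OC(=O)NS(=O)(=O)c3ccc(C)cc3)cc(C)c2O1`: 6600 nM
Compound 2 `CC(C)=CCC/C(C)=C/CC/C(C)=C/CC[C@]1(C)CCc2cc(OC(=O)NS(=O)(=O)c3ccc(Cl)cc3)c(C)c(C)c2O1`: > 10000 nM

Compound 2 stands at > 10000 nM, and this is a limit of this assay, not a number.

Compound 3 `CC(C)=CCC/C(C)=C/CC/C(C)=C/CC[C@]1(C)CCc2cc(OC(=O)NS(=O)(=O)c3ccc(Cl)cc3)cc(C)c2O1` comes from compound 2 through one small edit: hydrogen in place of methyl on an aromatic carbon. In words, hydrogen takes the place of methyl on an aromatic carbon, ortho to a large group and ortho to a methyl group.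

Within the data shown here, no measured pair shows this change on its own, so the data do not give its size. Among the measured compounds shown here, compound 1 supplies the only true number, 6600 nM, and the expectation leans on that value. In this assay a modest gain in inhibition is expected, with the estimated step being an at least 1.4-fold lower number from compound 2 to compound 3 (0.15 log units; that floor lies within the scatter). For compound 3 the estimated value is 7000 nM, with an expected range of 3000 nM to 15000 nM.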

Compound 3, half-maximal inhibitory concentration: > 10000 nM
Compound 3 gave a limit, no number; the forecaster's own chance of this, stated with the estimate: 30%; middle value at least 1.4-fold (0.15 log units) away from the limit.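

In this assay, taking the methyl off the aromatic carbon does not turn the result for the chloro compound into a readable number: compound 3, like compound 2, gives only a limit. The step between these two compounds cannot be read, because both sit at the same limit: the limit of > 10000 nM in this assay, at which 2 of the 3 values shown sit. The new result does add a comparison in one place, since chloro in place of methyl on an aromatic carbon gives an at least 1.5-fold higher number from compound 1 to compound 3 (0.18 log units; that floor lies within the scatter), which hints that this swap may matter, though that floor alone does not establish a real change.

From the compounds shown here alone, the size and direction of the effect of removing the methyl remain open. Also open, going by these compounds, is what a fluoro or methoxy group in place of the chloro would give.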